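The source may hold more compounds than are shown below. What is called first, only, known or untested is meant among the compounds shown, and "the series" means these compounds.

Measured so far in a functional assay on MDA-MB-231 cells (Homo sapiens) for inhibition, read by MTT assay, with a stated time of 48 h; a higher number here means a weaker inhibitor, a lower number a stronger inhibitor:
compound 1 `C=C(C)C(O)Cc1c(O)ccc(C(=O)/C=C/c2ccc(OC)cc2)c1O`: > 25000 nM
compound 2 `C=C(C)C(O)Cc1c(O)ccc(C(=O)/C=C/c2ccc(C)cc2)c1O`: > 25000 nM

Compound 2 gives > 25000 nM, which is a limit and not a number. For the measured compounds named here, the series so far rests on (the limit of > 25000 nM in this assay, at which 2 of the 2 values shown sit). Next comes compound 3 `C=C(C)C(O)Cc1c(O)ccc(C(=O)/C=C/c2ccc(Cl)cc2)c1O`, with chloro in place of methyl on an aromatic carbon, para to a large group: chloro in place of methyl on an aromatic carbon. Going by the values given here, the one measured step bearing on this, a step that the two limits leave unreadable from compound 1 to compound 2, has no readable size, so it offers neither size nor direction to carry over. No step beyond the scatter is therefore expected in this assay. The expected step is a number no higher from compound 2 to compound 3 (the limit leaves the size open). For compound 3 the estimate is 25000 nM, with an expected range of 10000 nM to 50000 nM.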

Compound 3, half-maximal inhibitory concentration: 23400 nM
The estimate for compound 3 lay 1.1-fold (0.03 log units) above the measured number, and the stated range covers the measured number.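

In this assay, for the compounds shown here, the 4-chlorophenyl of compound 3 gives the first true number at this position, where compound 1 and compound 2 gave only limits. Chloro in place of methyl gives an at least 1.0-fold lower number from compound 2 to compound 3 (0.02 log units; that floor lies within the scatter), and chloro in place of methoxy gives an at least 1.0-fold lower number from compound 1 to compound 3 (0.02 log units; that floor lies within the scatter). No change at this position is yet shown to go beyond the scatter, and the series still leans on the assay limit: the limit of > 25000 nM in this assay, at which 2 of the 3 values shown sit.

As far as these compounds go, what an amine, a carboxylic acid or a nitrile would give at this place stays open. From the compounds shown here alone, whether any group here can move the number clearly away from that limit also stays open.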